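A few compounds are considered here, and "the series" means these few. Any claim that something is new, unique, unknown or untested is made for them only; others in the source may bear on it.

In a functional assay on NCI-H522 cells (Homo sapiens) for inhibition, read by colorimetric assay and sulforhodamine B assay, with a stated time of 48 h (a lower number here means a stronger inhibitor of growth, a higher number a weaker inhibitor of growth), compound 1 `CCCCCCCCCCCC[C@@H](O)[C@H]1CC[C@H]([C@H](O)CCCCCCCCCCNC(=O)c2cccs2)O1` gives 1100 nM, while compound 2 `CCCCCCCCCCCC[C@@H](O)[C@H]1CC[C@H]([C@H](O)CCCCCCCCCCNC(=O)c2cncs2)O1` gives 19100 nM, the higher of the two numbers and so the weaker growth inhibitor. Compound 3 `CCCCCCCCCCCC[C@@H](O)[C@H]1CC[C@H]([C@H](O)CCCCCCCCCCNC(=O)c2ccsc2)O1` is still unmeasured and differs from compound 2 by thiophen-3-yl in place of 1,3-thiazol-5-yl on a carbonyl carbon. Among the compounds with values here, the only measured step that bears on this is a 17-fold higher number from compound 1 to compound 2 (1.24 log units; beyond the scatter), a large loss when 1,3-thiazol-5-yl replaced thiophen-2-yl. A large step in the opposite direction is therefore expected, although thiophen-3-yl is itself untested. The expected change is an 11-fold lower number from compound 2 to compound 3 (1.03 log units; beyond the scatter). The estimate for compound 3 is 1800 nM, within an expected range of 600 nM to 6000 nM.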

Compound 3, concentration for 50% growth inhibition: 1000 nM
For compound 3 the middle estimate is 1.8-fold (0.26 log units) above the measured one; low and high end bracket the measured number.
By their numbers in this assay, from the lowest: compounds 3 and 1 (each within the scatter of the next); then compound 2.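

Thiophen-3-yl does not carry the loss seen with 1,3-thiazol-5-yl on this carbonyl carbon in this assay (a 19-fold lower number from compound 2 to compound 3 (1.28 log units; beyond the scatter)). The change between the two thiophene attachments is small (a 1.1-fold lower number from compound 1 to compound 3 (0.04 log units; within the scatter)), within the scatter, so this position accepts thiophene attached either way. Among these three compounds, only the ring with 2 hetero atoms stands apart.

As far as these compounds go, whether a phenyl ring or a furan-2-yl ring would match the two thiophenes stays open. No evidence here explains why compound 2 differs so strongly from the others.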